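Chain extension on the anilide of compound 3

The source may report more compounds than this note shows. Statements on the series, on what has been measured and on what is new or still open speak of the compounds shown alone.

Compound 3 `CCC(=O)Nc1ccc(S(=O)(=O)Oc2ccccc2I)cc1` gives 7200 nM in a functional assay on HT-1080 cells (Homo sapiens) for antiproliferative activity, read by sulforhodamine B assay, with a stated time of 48 h (on this read-out higher numbers stand for weaker inhibition and lower numbers for stronger inhibition), and stands second highest of the three numbers shown. Compound 2 `CCC(=O)Nc1ccc(S(=O)(=O)Oc2ccccc2C(C)C)cc1` gives 2100 nM, and compound 1 `CC(=O)Nc1cccc(S(=O)(=O)Oc2ccccc2C(C)C)c1` gives 21000 nM. Going by the values given here, the only single-place step, a 3.4-fold higher number from compound 2 to compound 3 (0.54 log units; beyond the scatter), concerns the group on the ester side. Among the compounds with values here, compound 4 `CCCCCC(=O)Nc1ccc(S(=O)(=O)Oc2ccccc2I)cc1` differs from compound 3 by propyl in place of hydrogen on a saturated chain carbon, two bonds along the chain from a carbonyl carbon, a change on the amide side that no measured pair isolates: compound 1 and compound 2 differ in two places at once, so their gap cannot be assigned to chain length. No step beyond the scatter is therefore expected in this assay, with a step of a 1.2-fold lower number from compound 3 to compound 4 (0.08 log units; within the scatter) as the central guess. Compound 4 is estimated at 6000 nM, within 1800 nM to 20000 nM.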

Compound 4, half-maximal inhibitory concentration: 9600 nM
Compound 4: middle estimate off by 1.6-fold (0.20 log units), on the low side; measured number inside the range.
By their numbers in this assay, from the lowest: compound 2; then compounds 3 and 4 (each within the scatter of the next); then compound 1.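

With the iodo group unchanged, the amide side now has its first single-place step: in this assay, going from propanoyl to pentylcarbonyl gives a 1.3-fold higher number from compound 3 to compound 4 (0.12 log units; within the scatter) and so does not separate the two chains on this read-out. Going by these compounds alone, no earlier pair could show this, as compound 1 and compound 2 differ in two places at once. No measurement shown bears on this result.

On these data alone, whether a longer chain or a carboxylic acid in place of the pentylcarbonyl chain would give a step beyond the scatter remains open. Also open, as far as these compounds go, is whether the same extension behaves alike with isopropyl in place of iodo.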